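The source may report more compounds than this note shows. Statements on the series, on what has been measured and on what is new or still open speak of the compounds shown alone.

Measured so far in a functional assay on MCF7 cells (Homo sapiens) for antiproliferative activity, read by MTT assay; on this read-out lower numbers stand for stronger inhibition and higher numbers for weaker inhibition:
Compound 1 `C/C(=N/NC(=O)c1ccc(S(N)(=O)=O)cc1)c1ccc(F)cc1`: 31900 nM
Compound 2 `NS(=O)(=O)c1ccc(C(=O)N/N=C\c2ccccc2)cc1`: 14900 nM
Compound 3 `NS(=O)(=O)c1ccc(C(=O)N/N=C\c2ccc(Br)cc2)cc1`: 1370 nM

Compound 3, at 1370 nM, has the lowest of the three numbers, and its gaps to the other two lie beyond the scatter. Compound 4 `NS(=O)(=O)c1ccc(C(=O)N/N=C\c2ccc(Cl)cc2)cc1` has chloro in place of bromo on an aromatic carbon, para to a large group: chloro in place of bromo on an aromatic carbon. For the measured compounds named here, one measured step bears on this change: an 11-fold lower number from compound 2 to compound 3 (1.04 log units; beyond the scatter), a large step for bromo in place of hydrogen. Going by the values given here, no compound with chloro has been measured yet, so that step only hints that compound 4 may lie nearer to compound 3 than to compound 2. In this assay, a small rise within the scatter is expected: a 1.6-fold higher number from compound 3 to compound 4 (0.21 log units; within the scatter). For compound 4 the estimate is 2200 nM, with an expected range from 800 nM to 6500 nM.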

Compound 4, half-maximal inhibitory concentration: 36700 nM
Estimate against measurement, compound 4: 17-fold (1.22 log units) below; the measured number lies above the stated range.
By their numbers in this assay, from the lowest: compound 3; then compound 2; then compounds 1 and 4 (each within the scatter of the next).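

In this assay the change from 4-bromophenyl to 4-chlorophenyl gives a 27-fold higher number from compound 3 to compound 4 (1.43 log units; beyond the scatter) and so these two halogens cannot be treated as interchangeable at this place. Chloro in place of hydrogen gives a 2.5-fold higher number from compound 2 to compound 4 (0.39 log units; beyond the scatter) and runs the opposite way to an 11-fold lower number from compound 2 to compound 3 (1.04 log units; beyond the scatter) so, among hydrogen, bromo and chloro on this carbon, only bromo brings the lower number. Nothing measured here accounts for this gap between the two halogens.

As far as these compounds go, whether iodo, methoxy or an amine in the same place would follow bromo or chloro stays open.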